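A few compounds are considered here, and "the series" means these few. Any claim that something is new, unique, unknown or untested is made for them only; others in the source may bear on it.

Measured compounds:

Compound 1, `O=C(CC1c2ccccc2N=C(SCCCCCN2CCCC2)N1c1ccc(-c2ccc(F)cc2)cc1)NCc1ccc(F)cc1` — in a functional assay on HCT-116 cells (Homo sapiens) for cytotoxicity, read by MTT assay, with a stated time of 48 h (a higher number here means a weaker inhibitor, a lower number a stronger inhibitor), compound 1 gives 7700 nM.
Compound 3, `CN(C)CCCCCSC1=Nc2ccccc2C(CC(=O)NCc2ccc(F)cc2)N1c1ccc(-c2ccc(F)cc2)cc1` — in this assay compound 3 gives 9300 nM.
Compound 2, `CN(C)CCCCCSC1=Nc2ccccc2C(CC(=O)NCc2ccccc2)N1c1ccccc1` — in this assay compound 2 gives 38800 nM.

Compound 2 stands highest of the three numbers; its nearest neighbour is compound 3, and the gap between them is beyond the scatter, as is the gap to compound 1. The difference between the core of compound 2 and the core of compound 3 is not broken down here.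

Compound 3 and compound 1 differ in one place, (pyrrolidin-1-yl in place of dimethylamino on a saturated chain carbon, five bonds along the chain from a sulfur). That change gave a 1.2-fold lower number from compound 3 to compound 1 (0.08 log units; within the scatter), a step that lies within the scatter.

Compound 4, `O=C(CC1c2ccccc2N=C(SCCCCCN2CCCC2)N1c1ccccc1)NCc1ccccc1`, is not yet measured. It differs from compound 2 by pyrrolidin-1-yl in place of dimethylamino on a saturated chain carbon, five bonds along the chain from a sulfur, the same change as from compound 3 to compound 1, at the same place.

Because the earlier step of a 1.2-fold lower number from compound 3 to compound 1 (0.08 log units; within the scatter) stayed within the scatter, the step from compound 2 to compound 4 is expected to be about as small, a 1.2-fold lower number from compound 2 to compound 4 (0.08 log units; within the scatter). For compound 4 the estimate in this assay is 32000 nM, expected to fall between 15000 nM and 70000 nM.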

Compound 4, half-maximal inhibitory concentration: 31300 nM
Compound 4: the middle estimate sits 1.0-fold (0.01 log units) above what was measured; the measured number falls inside the stated range.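

In this assay, pyrrolidin-1-yl in place of dimethylamino on a saturated chain carbon, five bonds along the chain from a sulfur, gave a 1.2-fold lower number from compound 2 to compound 4 (0.09 log units; within the scatter), and this step matches the earlier one on the other core: the same change on two cores in this assay, a 1.2-fold lower number (0.08 log units; within the scatter) from compound 3 to compound 1 and a 1.2-fold lower number (0.09 log units; within the scatter) from compound 2 to compound 4, 1.0-fold (0.01 log units) apart, within the scatter of two such steps. The change therefore carries from one core to the other as a step within the scatter, so on these two cores the swap between these two amines leaves the number effectively unmoved. This rests on two pairs only and does not show that the step would stay this small on a further core or in another assay.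

Still open, on these data alone, is whether another amine at the end of the chain, such as piperidine or morpholine, or a shorter or longer chain, would give a step beyond the scatter. The two cores differ in more than one place, so the pairs shown do not assign the gap between them to any single one of those differences.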